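This account rests on a few compounds, and the source may have more. Where it says the series, first, only, none or still open, it means among the compounds named here.

Measured in an ADME assay on HepG2 cells (Homo sapiens) for cytotoxicity, with a stated time of 72 h; a higher number here means that more compound is needed for the effect, a lower number that less compound is needed:
Compound 1 `Cc1cc(NC(=O)Nc2cc(Cl)cc(Cl)c2)c2ccccc2n1`: > 25000 nM, a limit of the assay.
Compound 2 `Cc1cc(NC(=O)Nc2cccc(OC(F)(F)F)c2)c2ccccc2n1`: 13000 nM.
Compound 3 `Cc1cc(NC(=O)Nc2ccccc2F)c2ccccc2n1`: > 25000 nM, a limit of the assay.

Compound 3 has no exact value and stands at the limit of > 25000 nM in this assay, at which 2 of the 3 values shown sit. Only compound 2 gives a number, 13000 nM.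

Compound 4 `Cc1cc(NC(=O)Nc2cccc(Cl)c2)c2ccccc2n1` has 3-chlorophenyl in place of 2-fluorophenyl on an amide-type nitrogen. Among the compounds with values here, no measured pair isolates this change. In this assay, the expected step of an at least 1.1-fold lower number from compound 3 to compound 4 (0.05 log units; that floor lies within the scatter) is small, with none beyond the scatter and no firm direction. This expectation draws on compound 1, whose limit is > 25000 nM. It also allows for a measurable value like that of compound 2, 13000 nM. For compound 4 the estimate is 22000 nM, with an expected range of 11000 nM to 40000 nM.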

Compound 4, half-maximal effective concentration: 19000 nM
For compound 4 the middle estimate is 1.2-fold (0.06 log units) above the measured one; the range from low to high includes it.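

Chloro in place of trifluoromethoxy on an aromatic carbon gives the first comparison between two exact numbers in this assay, and a 1.5-fold higher number from compound 2 to compound 4 (0.16 log units; within the scatter) shows no change beyond the scatter. The steps of an at least 1.3-fold lower number from compound 3 to compound 4 (0.11 log units; that floor lies within the scatter) and an at least 1.3-fold lower number from compound 1 to compound 4 (0.11 log units; that floor lies within the scatter) have floors within the scatter, and their true size stays unread because each starts from a limit of the assay: the limit of > 25000 nM in this assay, at which 2 of the 4 values shown sit.

The compounds shown leave open whether an amine or a carboxylic acid on the aromatic carbon that carries chloro would move the number beyond the scatter. As far as these compounds go, whether the 3-chlorophenyl and 2-fluorophenyl groups truly differ also remains open.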